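The source may hold more compounds than are shown below. What is called first, only, known or untested is meant among the compounds shown, and "the series" means these compounds.

Of the compounds shown here, three built on one shared core have so far been tested in a functional assay on A-375 cells (Homo sapiens) for antiproliferative activity, read by MTT assay, with a stated time of 24 h, tested at 0.02 ug/mL; on this read-out higher numbers stand for a stronger effect at the one concentration tested and lower numbers for a weaker effect. Compound 1 `Cc1c(C(=O)Nc2c(F)cc(-c3cccc(F)c3)cc2F)nc2ccc(C(F)(F)F)cc2c1O` gives 1.28%. Compound 2 `Cc1ccc2nc(C(=O)Nc3c(F)cc(-c4cccc(F)c4)cc3F)c(C)c(C(=O)O)c2c1` gives 0.02%, and compound 3 `CCOc1ccc2nc(C(=O)Nc3c(F)cc(-c4cccc(F)c4)cc3F)c(C)c(C(=O)O)c2c1` gives 1.02%. Among these three numbers compound 3 stands second highest, with compound 1 nearest and compound 2 furthest, yet every gap lies within the scatter, so the three results cannot be told apart. Among the measured compounds shown here, the only single change measured so far is a number 1 percentage points higher from compound 2 to compound 3 (within the scatter), and it too lies within the scatter. For the measured compounds named here, the next compound is compound 4 `Cc1c(C(=O)Nc2c(F)cc(-c3cccc(F)c3)cc2F)nc2ccc(C(F)(F)F)cc2c1C(=O)O`. trifluoromethyl in place of ethoxy on an aromatic carbon This change is of a different kind from the one measured step, so that step offers little guidance beyond showing that a swap on this ring left the read-out unchanged. Compound 1 also carries a trifluoromethyl group and gives 1.28%, a number close to the others. Nothing measured here points to a step beyond the scatter. Compound 4 is therefore expected to give about 1%, within a range from 0% to 5%. The expected step of a number 0 percentage points lower from compound 3 to compound 4 (within the scatter) is estimated to stay within the scatter.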

Compound 4, a percentage reported as inhibition, at one concentration (the size of the read-out at that concentration, not a potency): 0.37%
The estimate for compound 4 lay 0.6 percentage points above the measured number; measured number inside the range.
By their numbers in this assay, from the lowest: compounds 2, 4, 3 and 1 (each within the scatter of the next).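

With trifluoromethyl, the position on the aromatic carbon of the shared core has now carried three groups of different size and atom makeup, and the read-out in this assay does not separate them: replacing ethoxy gives (a number 0.7 percentage points lower from compound 3 to compound 4 (within the scatter)), and replacing methyl gives (a number 0.4 percentage points higher from compound 2 to compound 4 (within the scatter)). The result also adds a second kind of change, at another place on the core, where carboxy in place of hydroxy gives (a number 0.9 percentage points lower from compound 1 to compound 4 (within the scatter)), so with trifluoromethyl held fixed this swap cannot be read as changing the result either. The data offer no measurement that would explain these small numbers or connect them to any feature of the groups.

On these data alone, it remains open whether an amine or a longer alkyl chain at the ethoxy position, or an amide in place of the carboxy group, would give a step beyond the scatter. As far as these compounds go, since a single low concentration was used, it is also open whether methyl, ethoxy and trifluoromethyl would still be indistinguishable at a higher concentration or after a longer exposure.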